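The source may hold more compounds than are shown below. What is called first, only, known or untested is meant among the compounds shown, and "the series" means these compounds.

In a functional assay on the whole organism (Tail, strain ICR) with Mus musculus as the target, in the tail flick test, with a stated time of 120 min, at a dose of 25 umol/kg by the oral route (on this read-out lower numbers stand for a weaker effect and higher numbers for a stronger effect at the one dose given), the three measured compounds gave:

Compound 1 `N=C(N)NCCC[C@H](NC(=O)CN(c1nc(Cl)nc2[nH]cnc12)C1CC1)C(=O)O`: 17%
Compound 2 `O=C(O)CNC(=O)CN(c1nc(Cl)nc2[nH]cnc12)C1CC1`: 19.8%
Compound 3 `CSCC[C@H](NC(=O)CN(c1nc(Cl)nc2[nH]cnc12)C1CC1)C(=O)O`: 5.67%

Compound 3 gives the lowest of these numbers: the steps of a number 11.3 percentage points lower from compound 1 to compound 3 (beyond the scatter) and a number 14.1 percentage points lower from compound 2 to compound 3 (beyond the scatter) both fall beyond the scatter. Compound 4 `CC(C)C[C@H](NC(=O)CN(c1nc(Cl)nc2[nH]cnc12)C1CC1)C(=O)O` has not been measured; it differs from compound 3 by isopropyl in place of (methylsulfanyl)methyl on a saturated chain carbon, two bonds along the chain from an amide-type nitrogen and a carbonyl carbon. Among the measured compounds shown here, no measured step exchanges one side chain for another of the same size, so the only guides are the two steps that attach or remove the side chain of compound 3, and both pointed downward. Replacing that side chain with a carbon-only one of equal size may or may not undo part of that drop; the data cannot say. Compound 4 is therefore estimated at 12% in this assay, between 2% and 25%, an expected step of a number 6.3 percentage points higher from compound 3 to compound 4 (within the scatter).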

Compound 4, a percentage reported as activity, at one dose (the size of the read-out at that dose, not a potency): 18.7%
Beside the measured number, compound 4's estimate is 6.7 percentage points below it; low and high end bracket the measured number.
By their numbers in this assay, from the lowest: compound 3; then compounds 1, 4 and 2 (each within the scatter of the next).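

In this assay, two side chains with the same count of heavy atoms do not read alike: a number 13 percentage points higher from compound 3 to compound 4 (beyond the scatter). The low number therefore belongs to the (methylsulfanyl)methyl group rather than to any side chain on this carbon: isobutyl in place of hydrogen gives a number 1.1 percentage points lower from compound 2 to compound 4 (within the scatter), and the change from the longer nitrogen-bearing chain gives a number 1.7 percentage points higher from compound 1 to compound 4 (within the scatter). No measurement here explains why the sulfur-bearing chain differs.

Going by these compounds, whether the sulfur atom itself matters remains open, as 2-methoxyethyl would test. So does how a benzyl group or an amine-ending chain would read on this carbon.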